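Removing tert-butoxycarbonyl from compound 2

The source may report more compounds than this note shows. Statements on the series, on what has been measured and on what is new or still open speak of the compounds shown alone.

In a functional assay on HT-29 cells (Homo sapiens) for inhibition, read by luminescence and CellTiter-Glo, with a stated time of 24 h (a higher number here means that more compound is needed for the effect, a lower number that less compound is needed), compound 1 `CN1C(=S)[C@@H](NC(=O)c2nc(Cc3ccccc3)n(CCC(F)(F)F)n2)COc2ccccc21` gives 1550 nM. Compound 2 `CN1C(=S)[C@@H](NC(=O)c2nc(Cc3ccccc3)n(C3CCN(C(=O)OC(C)(C)C)C3)n2)COc2ccccc21` gives only a limit in this assay, > 10000 nM, and not a number. The two differ in the group on the aromatic nitrogen, and the change gives an at least 6.4-fold higher number from compound 1 to compound 2 (0.80 log units; beyond the scatter), which lies beyond the scatter.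

Compound 3 `CN1C(=S)[C@@H](NC(=O)c2nc(Cc3ccccc3)n(C3CCNC3)n2)COc2ccccc21` differs from compound 2 by hydrogen in place of tert-butoxycarbonyl on an amine nitrogen in a ring. The five-membered non-aromatic ring stays. For the measured compounds named here, this is the only measured step that bears on the change, and it does so only indirectly. It introduced the tert-butoxycarbonyl together with the ring, so it cannot show what either part contributes. Removing that group alone has not been measured. A moderate move towards a lower number in this assay is therefore expected, though compound 3 could also remain at the limit. The estimate for compound 3 is about 3500 nM, with an expected range from 800 nM to 10000 nM. This expectation amounts to an at least 2.8-fold lower number from compound 2 to compound 3 (0.45 log units; beyond the scatter).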

Compound 3, half-maximal effective concentration: 1070 nM
For compound 3 the middle estimate is 3.3-fold (0.51 log units) above the measured one, and the stated range covers the measured number.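

Hydrogen in place of tert-butoxycarbonyl on the amine nitrogen of the five-membered non-aromatic ring now stands as a step of its own in this assay, and it gives an at least 9.3-fold lower number from compound 2 to compound 3 (0.97 log units; beyond the scatter). The ring is therefore not enough on its own to hold a compound at the limit, and with that ring kept and its nitrogen free, the group on the aromatic nitrogen can be changed with a 1.4-fold lower number from compound 1 to compound 3 (0.16 log units; within the scatter), so pyrrolidin-3-yl and 3,3,3-trifluoropropyl cannot be told apart at this position in this assay. The size of the step from the protected compound remains a bound and not an exact figure, as compound 2 stands at a limit and not at a number: the limit of > 10000 nM in this assay, at which 1 of the 3 values shown sits.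

The compounds shown leave open whether a smaller group on the ring nitrogen, such as methyl or acetyl, would stay close to compound 3 or move towards the limit of compound 2. They also leave open whether an open chain bearing an amine could stand in place of the five-membered ring on the aromatic nitrogen and give a comparable number.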